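Ester Variation on an Iridoid Glycoside Core

The source may hold more compounds than are shown below. What is called first, only, known or untested is meant among the compounds shown, and "the series" means these compounds.

Measured compounds:
Compound 1 `C=C(C)CCOC(=O)C[C@@H]1C(C(=O)OC)=CO[C@@H](O[C@@H]2O[C@H](CO)[C@@H](O)[C@H](O)[C@H]2O)/C1=C/C` gives in a functional assay on SK-BR-3 cells (Homo sapiens) for antiproliferative activity, read by MTT assay, with a stated time of 72 h (on this read-out lower numbers stand for stronger inhibition and higher numbers for weaker inhibition), a value of > 15000 nM, which is a limit of the assay.
Compound 2 `C/C=C1/[C@H](O[C@@H]2O[C@H](COC(C)=O)[C@@H](OC(C)=O)[C@H](OC(C)=O)[C@H]2OC(C)=O)OC=C(C(=O)O)[C@H]1CC(=O)O` gives in this assay a value of > 20000 nM, also a limit.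
Compound 3 `C=C(C)CCOC(=O)C[C@@H]1C(C(=O)OC)=CO[C@@H](O[C@@H]2O[C@H](COC(C)=O)[C@@H](OC(C)=O)[C@H](OC(C)=O)[C@H]2OC(C)=O)/C1=C/C` gives in this assay a value of > 15000 nM, also a limit.

Compound 1 stands nowhere in particular among the numbers shown: in this assay it is known only as a limit, and the two other measured compounds are likewise known only as limits, two of them sitting at the limit of > 15000 nM in this assay, at which 2 of the 3 values shown sit, and one at the limit of > 20000 nM in this assay, at which 1 of the 3 values shown sits. Among the compounds with values here, no measured pair differs in a single place, so no measured step is available and no ranking can be read from these three.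

Compound 4 `C/C=C1/[C@H](O[C@@H]2O[C@H](CO)[C@@H](O)[C@H](O)[C@H]2O)OC=C(C(=O)OC)[C@H]1CC(=O)OCc1ccc2c(c1)OCCO2` differs from compound 1 by 2,3-dihydro-1,4-benzodioxin-6-yl in place of 2-methylprop-2-en-1-yl on a saturated chain carbon bound to an oxygen next to a carbonyl group. Cut one bond further out, the same difference reads 3-methylbut-3-en-1-yl to (2,3-dihydro-1,4-benzodioxin-6-yl)methyl.

With only limits in hand, the direction of this step cannot be read from the data. The expectation is that the step of an at least 1.2-fold lower number from compound 1 to compound 4 (0.09 log units; that floor lies within the scatter) is small and that compound 4 remains at or near the limit. Compound 4 is accordingly estimated at 12000 nM, with a range from 3000 nM to 40000 nM.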

Compound 4, half-maximal inhibitory concentration: > 15000 nM
Compound 4 was reported as a limit (the forecaster's own chance of this, stated with the estimate: 60%); middle value at least 1.2-fold (0.09 log units) from the limit.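

In this assay compound 4 gives > 15000 nM, which is a limit of the assay. Compound 1 is likewise known only as a limit, so no step can be read between compound 1 and compound 4. The compounds shown leave open whether any ester on the shared core gives a measurable value in this assay.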